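Swapping Methyl for Trifluoromethyl in Compound 1

The source may hold more compounds than are shown below. What is called first, only, known or untested is meant among the compounds shown, and "the series" means these compounds.

Measured so far in a functional assay on PC-3 cells (Homo sapiens) for cytotoxicity, read by MTT assay, with a stated time of 72 h; a lower number here means a stronger inhibitor, a higher number a weaker inhibitor:
- compound 1 `Cc1c(C(=O)Nc2ccc(Oc3ccnc4[nH]ccc34)cc2)nnn1-c1ccccc1F` gives 3450 nM
- compound 2 `Cc1c(C(=O)Nc2ccc(Oc3ccnc4[nH]ccc34)cc2)nnn1-c1ccc(F)cc1` gives 3450 nM

Compound 1 stands level with compound 2 at the digits shown; the step of no change at the digits printed from compound 1 to compound 2 (within the scatter) lies within the scatter of repeated measurements, so the two cannot be told apart. The change under consideration leads to compound 3 `O=C(Nc1ccc(Oc2ccnc3[nH]ccc23)cc1)c1nnn(-c2ccccc2F)c1C(F)(F)F`. Compared with compound 1, the difference is trifluoromethyl in place of methyl on an aromatic carbon; the new group sits on an aromatic carbon of a five-membered aromatic ring with 3 nitrogen, next to the ring atom that bears a 2-fluorophenyl group. Among the measured compounds shown here, no measured step touches this position: the only recorded step, from compound 1 to compound 2, replaces 2-fluorophenyl with 4-fluorophenyl and changed nothing beyond the scatter, so it offers no guide to what a trifluoromethyl on the core does. For the measured compounds named here, with no comparable step, the expectation for compound 3 is an activity close to that of compound 1, and the step of a 1.0-fold higher number from compound 1 to compound 3 (0.01 log units; within the scatter) is expected to stay within the scatter. The estimate for compound 3 in this assay is 3500 nM, with a plausible range from 1000 nM to 12000 nM.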

Compound 3, half-maximal inhibitory concentration: 3690 nM
Compound 3: the middle estimate sits 1.1-fold (0.02 log units) below what was measured, and the stated range covers the measured number.
By their numbers in this assay, from the lowest: compounds 1, 2 and 3 (each within the scatter of the next).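

In this assay, the position that carries methyl in compound 1 now has a measured change of its own, and the step is a 1.1-fold higher number from compound 1 to compound 3 (0.03 log units; within the scatter) for trifluoromethyl in place of methyl. The earlier compounds shown here differed only in where the fluorine sat on the fluorophenyl group, whereas this result shows that a group of 4 heavy atoms can replace one of 1 heavy atom on this aromatic carbon, next to the ring atom that bears a 2-fluorophenyl group, without a change that can be told from the scatter in this cell assay. Nothing measured here on these groups accounts for that outcome, so the result stands without an explanation.

The compounds shown leave open whether a different group on this carbon, such as an amine, a carboxylic acid or a longer chain like ethyl, would move the number beyond the scatter. They also leave open whether trifluoromethyl in place of methyl would give the same result alongside the 4-fluorophenyl group of compound 2.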